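This account rests on a few compounds, and the source may have more. Where it says the series, first, only, none or still open, it means among the compounds named here.

Measured so far in a functional assay on MDA-MB-231 cells (Homo sapiens) for cytotoxicity, read by MTT assay, with a stated time of 72 h; a higher number here means a weaker inhibitor, a lower number a stronger inhibitor:

- compound 1 `Cc1cccc(Cl)c1NC(=O)CN1CCN(c2nnc(Cc3ccncc3)c3ccccc23)CC1`: 2670 nM
- compound 2 `O=C(CN1CCN(c2nnc(Cc3ccncc3)c3ccccc23)CC1)Nc1ccc(F)c(F)c1`: 0.84 nM
- compound 3 `Cc1ccc(F)cc1NC(=O)CN1CCN(c2nnc(Cc3ccccc3)c3ccccc23)CC1`: 19200 nM

Compound 3 gives the highest of the three numbers in this assay; the nearest is compound 1, and the gap to compound 2 is the widest in the set. Compound 1 and compound 3 differ in two places, so their values alone are compared here; compound 1 sits well below compound 3.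

The next compound is compound 4 `O=C(CN1CCN(c2nnc(Cc3ccccc3)c3ccccc23)CC1)Nc1ccc(F)c(F)c1`. Relative to compound 3 the change is 3,4-difluorophenyl in place of 5-fluoro-2-methylphenyl on an amide-type nitrogen.

Among the compounds with values here, one measured step bears on this: a 3200-fold lower number from compound 1 to compound 2 (3.50 log units; beyond the scatter), where 3,4-difluorophenyl replaced 2-chloro-6-methylphenyl on the same amide-type nitrogen, against a different shared core. Within the data shown here, the group leaving compound 3 is not the same as the one leaving compound 1, and the core differs, so the transfer is not exact; still, a large drop in this assay is expected for compound 4, in the same direction.

Compound 4 is therefore estimated at 10 nM, with a range of 0.5 nM to 300 nM, which is expected to amount to a 1900-fold lower number from compound 3 to compound 4 (3.28 log units; beyond the scatter).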

Compound 4, half-maximal inhibitory concentration: 2750 nM
Compound 4: middle estimate off by 280-fold (2.44 log units), on the low side; the whole stated range lies below it.
By their numbers in this assay, from the lowest: compound 2; then compounds 1 and 4 (each within the scatter of the next); then compound 3.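

In this assay the change to 3,4-difluorophenyl on the amide-type nitrogen gives only a 7.0-fold lower number from compound 3 to compound 4 (0.84 log units; beyond the scatter) with phenyl on the chain carbon, against a 3200-fold lower number from compound 1 to compound 2 (3.50 log units; beyond the scatter) with pyridin-4-yl there and a different group leaving, so the size of this change depends on its partner group. With 3,4-difluorophenyl held fixed, the other place gives a 3300-fold higher number from compound 2 to compound 4 (3.52 log units; beyond the scatter), and among the compounds shown the low number of compound 2 is lost when either group is replaced. Nothing on hand accounts for this dependence.

Open, on these data alone, is whether pyridin-3-yl or 4-methoxyphenyl on the chain carbon would keep the low number seen with pyridin-4-yl. Also open, as far as these compounds go, is whether 4-fluorophenyl on the amide-type nitrogen would serve as well as 3,4-difluorophenyl.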